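Chain shortening on the cyanoguanidine side arm

A few compounds are considered here, and "the series" means these few. Any claim that something is new, unique, unknown or untested is made for them only; others in the source may bear on it.

Compound 3 `C/N=C(/NC#N)NCCCCn1nc(-c2ccccc2)cc(C)c1=O` gives 68.6% in a functional assay on the whole organism with Rattus norvegicus as the target, at a dose of 100 mg/kg (on this read-out higher numbers stand for more inhibition at the one dose given (going by the name of the read-out) and lower numbers for less inhibition), and stands highest of the three numbers at hand. Compound 1 `C/N=C(/NC#N)NCCCn1nc(-c2ccccc2)ccc1=O` gives 40.5% in this assay, and compound 2 `CC/N=C(/NC#N)NCCCn1nc(-c2ccccc2)cc(C)c1=O` gives 23.5%; both lie beyond the scatter below compound 3.

Compound 4 `C/N=C(/NC#N)NCCCn1nc(-c2ccccc2)cc(C)c1=O` is not yet measured. Its difference from compound 3 is a group of 7 heavy atoms (3 carbon, 4 nitrogen; no ring) in place of a group of 8 heavy atoms (4 carbon, 4 nitrogen; no ring), on a saturated chain carbon, three bonds along the chain from an aromatic nitrogen.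

For the measured compounds named here, the one measured step at the same place is a number 45.1 percentage points higher from compound 2 to compound 3 (beyond the scatter); there the side arm changed in a different way, so it shows that this position is sensitive but does not fix the direction for compound 4. Going by the values given here, compound 4 shares its side arm with compound 1, which lacks only the ring methyl; no step between them is known, so compound 1, with its value of 40.5%, can only serve as a loose anchor. On this basis a drop from compound 3 is expected for compound 4, of about a number 23.6 percentage points lower from compound 3 to compound 4 (beyond the scatter), with wide uncertainty.

Compound 4 is therefore estimated at 45% in this assay, with a range from 20% to 70%.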

Compound 4, a percentage reported as inhibition, in the whole organism at one dose (the size of the read-out at that dose, not a potency): 42.8%
Estimate against measurement, compound 4: 2.2 percentage points above; the measured number falls inside the stated range.
By their numbers in this assay, from the lowest: compound 2; then compounds 1 and 4 (each within the scatter of the next); then compound 3.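

Going from the side arm of 8 heavy atoms to the one of 7 heavy atoms, with the end methyl kept, gives a number 25.8 percentage points lower from compound 3 to compound 4 (beyond the scatter) in this assay and shows that the chain length on the aromatic nitrogen counts by itself. Hydrogen in place of methyl on the saturated chain carbon bound to a double-bonded nitrogen gives a number 19.3 percentage points higher from compound 2 to compound 4 (beyond the scatter) and shows that the far end of the arm counts as well, so the earlier a number 45.1 percentage points higher from compound 2 to compound 3 (beyond the scatter) combines two changes that each matter on this read-out. Methyl in place of hydrogen on an aromatic carbon gives a number 2.3 percentage points higher from compound 1 to compound 4 (within the scatter) and so leaves no visible mark in this pair, which places the sensitivity of the series in the side arm rather than at that ring carbon.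

The compounds shown leave open whether a longer chain than that of compound 3, or an amine or a carboxylic acid at the end of the arm in place of the cyanoguanidine, would carry the trend further, and whether the order would hold at other doses. The data offer nothing that explains these steps.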